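From 4-methylpiperazin-1-yl to 4-propylpiperazin-1-yl

The source may report more compounds than this note shows. Statements on the series, on what has been measured and on what is new or still open speak of the compounds shown alone.

In a functional assay on A549 cells (Homo sapiens) for cytotoxicity, read by MTT assay, with a stated time of 72 h (a lower number here means a stronger inhibitor, a higher number a weaker inhibitor), compound 1 (`O=C1c2c[n+]([O-])c3ccccc3c2C(=O)c2c1c1ccccc1n2Cc1cn([C@H]2O[C@H](CO)[C@@H](O)[C@H]2O)nn1`) gives 2680 nM, compound 2 (`O=C1c2c[n+]([O-])c3ccccc3c2C(=O)c2c1c1ccccc1n2Cc1cn(CC(O)CO)nn1`) gives 880 nM and compound 3 (`CN1CCN(CCCCn2c3c(c4ccccc42)C(=O)c2c[n+]([O-])c4ccccc4c2C3=O)CC1`) gives 90 nM, the lowest of the three numbers. The measured changes are a 3.0-fold lower number from compound 1 to compound 2 (0.48 log units; beyond the scatter) and a 9.8-fold lower number from compound 2 to compound 3 (0.99 log units; beyond the scatter). Compound 4 (`CCCN1CCN(CCCCn2c3c(c4ccccc42)C(=O)c2c[n+]([O-])c4ccccc4c2C3=O)CC1`) differs from compound 3 by ethyl in place of hydrogen on a saturated chain carbon bound to an amine nitrogen in a ring, which turns methyl to propyl. Neither measured step alters this place: each exchanges a whole group, the second being the nearer, as it installs the 4-methylpiperazin-1-yl group itself. Neither sets a size for so small a change. Only a step within the scatter is expected, estimated as a 1.1-fold lower number from compound 3 to compound 4 (0.05 log units; within the scatter). For compound 4 the estimated value is 80 nM, with an expected range of 30 nM to 220 nM.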

Compound 4, half-maximal inhibitory concentration: 320 nM
Compound 4: the middle estimate sits 4.0-fold (0.60 log units) below what was measured, outside the stated range (above it).
By their numbers in this assay, from the lowest: compound 3; then compound 4; then compound 2; then compound 1.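

Going from 4-methylpiperazin-1-yl to 4-propylpiperazin-1-yl is not a neutral change: in this assay, ethyl in place of hydrogen on a saturated chain carbon bound to an amine nitrogen in a ring gives a 3.6-fold higher number from compound 3 to compound 4 (0.55 log units; beyond the scatter). The exchange of the triazole-bearing group keeps a real advantage with the propyl group, at a 2.8-fold lower number from compound 2 to compound 4 (0.44 log units; beyond the scatter), but this is smaller than a 9.8-fold lower number from compound 2 to compound 3 (0.99 log units; beyond the scatter). No measurement shown here accounts for the difference. With only methyl and propyl at this place, no trend with chain length can be drawn. Going by these compounds, it remains open how an ethyl group, a butyl chain or a 2-hydroxyethyl group there would compare.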